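Cyclopentyl in place of but-2-en-1-yl on the ring nitrogen

A few compounds are considered here, and "the series" means these few. Any claim that something is new, unique, unknown or untested is made for them only; others in the source may bear on it.

Of the compounds shown here, three sharing one core have been measured in a physicochemical assay for lipophilicity; a higher number here means a more lipophilic compound, a lower number a more polar compound. Compound 1 `Brc1cccc(N(CC2CC2)C2=NCCN2)c1Br` gives -0.41. Compound 2 `CC(C)CN(C1=NCCN1)c1c(Br)cccc1Br` gives -0.64. Compound 3 `C/C=C/CN(C1=NCCN1)c1c(Br)cccc1Br` gives -0.49, a value lying within the scatter of both compound 1 and compound 2. Among the compounds with values here, the single step between neighbours, a number 0.15 log units higher from compound 2 to compound 3 (within the scatter), also stayed within the scatter. Compound 4 `Brc1cccc(Br)c1N(C1=NCCN1)C1CCCC1` differs from compound 3 as follows: cyclopentyl in place of but-2-en-1-yl on a nitrogen on an aromatic ring. Within the data shown here, no measured step exchanges a chain for a ring of this kind, so the bearing of the one known step is slight. A small rise in this assay is nevertheless expected, a number 0.39 log units higher from compound 3 to compound 4 (beyond the scatter). Compound 4 is thus estimated at -0.1, with a range from -0.5 to 0.3.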

Compound 4, distribution coefficient: -0.29
The estimate for compound 4 lay 0.19 log units above the measured number, within the range that was stated.
By their numbers in this assay, from the lowest: compounds 2, 3, 1 and 4 (each within the scatter of the next, the first and the last beyond it).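

In this assay the cyclopentyl ring on a nitrogen on an aromatic ring gives a number 0.20 log units higher from compound 3 to compound 4 (within the scatter) and so cannot be told apart from but-2-en-1-yl. Against isobutyl the same ring gives a number 0.35 log units higher from compound 2 to compound 4 (beyond the scatter) and this is the first step at this position to pass the scatter, though only modestly. No evidence at hand accounts for either step.

From the compounds shown here alone, how this assay responds at this nitrogen to a larger ring such as cyclohexyl, or to a chain ending in an amine, remains open.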